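Changing the phenyl group: what to expect of compound 3

This account rests on a few compounds, and the source may have more. Where it says the series, first, only, none or still open, it means among the compounds named here.

Compound 1 `O=C(Nc1ccc2[nH]c(=O)oc2c1)C(=O)N1CCN(c2ccc(F)c(F)c2)CC1`: 13%
Compound 2 `O=C(Nc1ccc2[nH]c(=O)oc2c1)C(=O)N1CCN(c2ccc(F)c(Cl)c2)CC1`: 24.6%

In an ADME assay on the whole organism (Rattus norvegicus, strain Sprague-Dawley) for pharmacokinetics, using cassette dosing, at a dose of 1 mg/kg by the oral route (on this read-out higher numbers stand for higher oral bioavailability and lower numbers for lower oral bioavailability), compound 2 stands highest of the two measured compounds, at 24.6%. The next compound, compound 3 `COc1ccc(N2CCN(C(=O)C(=O)Nc3ccc4[nH]c(=O)oc4c3)CC2)cc1F`, carries 3-fluoro-4-methoxyphenyl in place of 3-chloro-4-fluorophenyl on an amine nitrogen in a ring. Within the data shown here, only one measured step bears on this change: a number 11.6 percentage points higher from compound 1 to compound 2 (beyond the scatter), with chloro in place of fluoro on an aromatic carbon. Among the measured compounds shown here, it is a limited guide, since no measured compound carries methoxy. Compound 3 has no chloro, and neither does compound 1, at 13%, so a lower number is expected. The step expected in this assay is a number 7.6 percentage points lower from compound 2 to compound 3 (within the scatter), an estimate that leans downward and remains uncertain. For compound 3 the estimated value is 17%, with an expected range of 6% to 33%.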

Compound 3, oral bioavailability: 0.6%
The estimate for compound 3 lay 16.4 percentage points above the measured number, outside the stated range (below it).
By their numbers in this assay, from the lowest: compound 3; then compound 1; then compound 2.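

In this assay the group on the ring nitrogen can move the number down as well as up: 3-fluoro-4-methoxyphenyl in place of 3-chloro-4-fluorophenyl gives a number 24 percentage points lower from compound 2 to compound 3 (beyond the scatter). Losing chloro does not account for the whole fall, as compound 1 also has no chloro, and bringing in methoxy still gives a number 12.4 percentage points lower from compound 1 to compound 3 (beyond the scatter). No measurement shown here explains why methoxy goes with such a low number.

From the compounds shown here alone, it remains open whether this fall is particular to methoxy or would also come with a longer ether such as ethoxy, or with an amine in its place on the phenyl ring. Also open, going by these compounds, is whether chloro would raise the number on a phenyl ring that also carries methoxy.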